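A few compounds are considered here, and "the series" means these few. Any claim that something is new, unique, unknown or untested is made for them only; others in the source may bear on it.

Of the compounds shown here, three of one series have been tested so far in a functional assay on CCRF-CEM cells (Homo sapiens) for cytotoxicity; a lower number here means a stronger inhibitor, a higher number a weaker inhibitor. Compound 1 `COc1ccc(NC(=O)/C=C/C(=O)N2C/C(=C\c3ccc([N+](=O)[O-])cc3)C(=O)/C(=C/c3ccc([N+](=O)[O-])cc3)C2)cc1` gives 760 nM in this assay, and compound 2 `Cc1ccc(NC(=O)/C=C/C(=O)N2C/C(=C\c3ccc([N+](=O)[O-])cc3)C(=O)/C(=C/c3ccc([N+](=O)[O-])cc3)C2)cc1C` gives 700 nM. The two differ in a single place: 4-methoxyphenyl in place of 3,4-dimethylphenyl on an amide-type nitrogen. The step of a 1.1-fold higher number from compound 2 to compound 1 (0.04 log units; within the scatter) is therefore one that the assay cannot separate from repetition noise. Compound 3 `Cc1ccc(NC(=O)/C=C/C(=O)N2C/C(=C\c3ccccc3)C(=O)/C(=C/c3ccccc3)C2)cc1C` gives 7100 nM in this assay, the highest number of the three; its value stands well apart from those of compound 1 and compound 2, both gaps lying beyond the scatter. How the core of compound 3 differs from the core of compound 2 is not broken down here.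

Compound 4 `COc1ccc(NC(=O)/C=C/C(=O)N2C/C(=C\c3ccccc3)C(=O)/C(=C/c3ccccc3)C2)cc1` has not yet been measured. It is related to compound 3 by 4-methoxyphenyl in place of 3,4-dimethylphenyl on an amide-type nitrogen. This is the same change, at the same place on an amide-type nitrogen whose other neighbour is a carbonyl carbon, that links compound 2 to compound 1. Going by the values given here, on the core shared by compound 3 and compound 4, no other pair shows it.

Among the compounds with values here, because the only prior example of this change, a 1.1-fold higher number from compound 2 to compound 1 (0.04 log units; within the scatter), was within the scatter, the step of a 1.1-fold higher number from compound 3 to compound 4 (0.02 log units; within the scatter) is expected to be small as well. Compound 4 is thus estimated to give about 7500 nM in this assay, most likely between 3500 nM and 16000 nM.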

Compound 4, half-maximal inhibitory concentration: 510 nM
Compound 4: the middle estimate sits 15-fold (1.17 log units) above what was measured, and the stated range ends above it.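

In this assay, the same replacement of 3,4-dimethylphenyl by 4-methoxyphenyl on the amide-type nitrogen gives a 14-fold lower number from compound 3 to compound 4 (1.14 log units; beyond the scatter), a large step, whereas it had no readable effect on the other core: the same change on two cores in this assay, a 1.1-fold higher number (0.04 log units; within the scatter) from compound 2 to compound 1 and a 14-fold lower number (1.14 log units; beyond the scatter) from compound 3 to compound 4, 15-fold (1.18 log units) apart, beyond the scatter of two such steps. In this series, then, the step measured on one core did not carry over to the other, and a change that is silent on one core cannot be assumed to be silent on another. This does not show which feature of the two cores separates the results, or which of the two steps is the more typical, since each rests on a single pair of compounds and no general rule can be drawn from two cores.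

The compounds shown leave open whether other groups on the amide-type nitrogen, such as a plain phenyl or a chlorophenyl, would also respond differently on the two cores. They also leave open whether a core carrying a different group on its two benzylidene arms, such as a nitrile or a dimethylamino group, would follow the pattern of compound 3 and compound 4 or that of compound 1 and compound 2.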